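The compounds below may be only part of what the source reports. "The series", "measured", "known", "first", "only" and "open" are said of these compounds alone.

Working notes on the series. Compound 1 `CCCn1c(=O)c2nc(-c3cnn(Cc4c(F)cccc4F)c3)[nH]c2n(CCC)c1=O` gives 390 nM in an in vitro assay on HEK293 cells for displacement of a labelled ligand from adenosine receptor A2b (Homo sapiens) (a lower number here means a stronger inhibitor, a higher number a weaker inhibitor), and so holds the higher of the two numbers shown; compound 3 `CCCn1c(=O)c2nc(-c3cnn(Cc4cc(C(F)(F)F)cc(Cl)c4F)c3)[nH]c2n(CCC)c1=O` gives 360 nM in this assay, and the two lie within the scatter of each other. Compound 2 `CCCn1c(=O)c2c(nc(-n3cccn3)n2Cc2ccccc2)n(CCC)c1=O` reaches only the limit > 5800 nM in this assay, which is a limit of the method and not a number, as noted in the limit of > 5800 nM in this assay, at which 1 of the 3 values shown sits.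

Compound 4 `CCCn1c(=O)c2nc(-c3cnn(Cc4ccc(F)c(C(F)(F)F)c4)c3)[nH]c2n(CCC)c1=O` is not yet measured. It differs from compound 1 as follows: 4-fluoro-3-(trifluoromethyl)phenyl in place of 2,6-difluorophenyl on a saturated chain carbon bound to an aromatic nitrogen. Compound 3 shows that a trifluoromethyl-bearing phenyl at this position sits close to compound 1, so the step from compound 1 to compound 4 is expected to be a 1.2-fold lower number from compound 1 to compound 4 (0.09 log units; within the scatter), none beyond the scatter. In this assay compound 4 is estimated at 320 nM, expected between 120 nM and 850 nM.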

Compound 4, inhibition constant: 640 nM
Compound 4: middle estimate off by 2.0-fold (0.30 log units), on the low side; measured number inside the range.
By their numbers in this assay, from the lowest: compounds 3, 1 and 4 (each within the scatter of the next). At a limit, above all of these: compound 2.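

In this assay, within the data shown here, the first readable single-place step at this position, 4-fluoro-3-(trifluoromethyl)phenyl in place of 2,6-difluorophenyl on a saturated chain carbon bound to an aromatic nitrogen, gives a 1.6-fold higher number from compound 1 to compound 4 (0.22 log units; within the scatter) and no more. The position thus takes this exchange, with 11 heavy atoms entering for 8, without a change beyond the scatter. Nothing measured here bears on a cause for this step.

Still open, on these data alone, is whether a phenyl carrying an amine or a carboxylic acid would hold a number in this range. As far as these compounds go, a cyclohexyl ring in place of the phenyl, or a longer chain to the aromatic nitrogen, is equally open.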